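The source may hold more compounds than are shown below. What is called first, only, known or untested is meant among the compounds shown, and "the series" means these compounds.

Among the measured compounds shown here, compound 2 `CCCCCCSc1cc(-c2ccccc2)c(-c2ccccc2)nn1` stands at the higher of the two numbers so far recorded in an assay on microsomes from liver for inhibition of sterol O-acyltransferase 1 (Rattus norvegicus); on this read-out higher numbers stand for weaker inhibition and lower numbers for stronger inhibition; there compound 2 gives 62000 nM. For the measured compounds named here, its only measured neighbour is compound 1 `CCCCCCNc1cc(-c2ccccc2)c(-c2ccccc2)nn1`, and in this assay compound 1 gives 24000 nM, so the step of a 2.6-fold higher number from compound 1 to compound 2 (0.41 log units; beyond the scatter) is a modest one. Compound 3 `CCCCCC[S+]([O-])c1cc(-c2ccccc2)c(-c2ccccc2)nn1` differs from compound 2 by a group of 8 heavy atoms (6 carbon, 1 oxygen, 1 sulfur; no ring) in place of a group of 7 heavy atoms (6 carbon, 1 sulfur; no ring), on an aromatic carbon, on an aromatic carbon next to the ring nitrogen. Going by the values given here, no measured pair shows this particular exchange: the step from compound 1 to compound 2 concerns a different group leaving the same position, and it shows only that an exchange at this place has shifted the number modestly. The expectation is therefore uncertain, and a step of a 1.3-fold higher number from compound 2 to compound 3 (0.11 log units; within the scatter) is estimated with a wide range. On that basis compound 3 is expected to give about 80000 nM in this assay, somewhere between 25000 nM and 250000 nM.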

Compound 3, half-maximal inhibitory concentration: 75000 nM
Compound 3: the middle estimate sits 1.1-fold (0.03 log units) above what was measured; the range from low to high includes it.
By their numbers in this assay, from the lowest: compound 1; then compounds 2 and 3 (each within the scatter of the next).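

In this assay, the new group differs from hexylsulfanyl by one added oxygen, and this change on the aromatic carbon next to the ring nitrogen gives a 1.2-fold higher number from compound 2 to compound 3 (0.08 log units; within the scatter). Compounds 2 and 3 therefore cannot be told apart here, so the added oxygen shows no measurable effect on the number. Compared with the hexylamino group, however, the new group gives a 3.1-fold higher number from compound 1 to compound 3 (0.49 log units; beyond the scatter), which places both sulfur-containing compounds on the weaker side of compound 1, and nothing measured here explains these steps.

The compounds shown leave open whether a sulfur carrying two oxygens would also match compound 2. They also leave open whether a butyl chain or a longer octyl chain on the nitrogen, or a carboxylic acid at the end of the chain, would give a lower number than compound 1.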